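Moving the hydroxy group: what to expect of compound 3

The source may report more compounds than this note shows. Statements on the series, on what has been measured and on what is new or still open speak of the compounds shown alone.

For the measured compounds named here, in a functional assay on HT-29 cells (Homo sapiens) for inhibition, read by sulforhodamine B assay, with a stated time of 48 h (on this read-out higher numbers stand for weaker inhibition of growth and lower numbers for stronger inhibition of growth), compound 2 (`O=C(Cc1csc2nc(-c3ccc(Br)cc3)cn12)N/N=C/c1ccccc1O`) gives 6030 nM and holds the lower of the two numbers so far, while compound 1 (`O=C(Cc1csc2nc(-c3ccc(Br)cc3)cn12)N/N=C/c1ccccc1`) gives 43700 nM as the only other value. Compound 3 (`O=C(Cc1csc2nc(-c3ccc(Br)cc3)cn12)N/N=C/c1ccc(O)cc1`) changes one thing: 4-hydroxyphenyl in place of 2-hydroxyphenyl on a carbon with a double bond to nitrogen with 4-hydroxyphenyl in place of 2-hydroxyphenyl on a carbon with a double bond to nitrogen. Going by the values given here, the one measured step that bears on this is a 7.2-fold lower number from compound 1 to compound 2 (0.86 log units; beyond the scatter) from hydroxy in place of hydrogen on an aromatic carbon, modest but beyond the scatter. Among the compounds with values here, no measured step shows what moving a hydroxy does, so that step only sets a rough scale. Compound 3 keeps a hydroxy, so a small rise is expected, with the estimated change being a 2.0-fold higher number from compound 2 to compound 3 (0.30 log units; within the scatter) in this uncertain case. Compound 3 is estimated at 12000 nM within a range of 3500 nM to 35000 nM as the expected span.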

Compound 3, concentration for 50% growth inhibition: 50100 nM
Compound 3: middle estimate off by 4.2-fold (0.62 log units), on the low side, and the stated range ends below it.
By their numbers in this assay, from the lowest: compound 2; then compounds 1 and 3 (each within the scatter of the next).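

In this assay, where the hydroxy sits on the ring counts for a great deal: 4-hydroxyphenyl in place of 2-hydroxyphenyl gives an 8.3-fold higher number from compound 2 to compound 3 (0.92 log units; beyond the scatter) and so undoes the improvement seen earlier. Having a hydroxy on this ring is therefore not enough by itself, since adding one in the 4-hydroxyphenyl form gives a 1.1-fold higher number from compound 1 to compound 3 (0.06 log units; within the scatter) and leaves compound 3 no different from compound 1, which has no hydroxy at all. Nothing available here explains why the two hydroxyphenyl groups differ.

Still open, on these data alone, is whether a methoxy or an amine on this ring would follow the pattern of 2-hydroxyphenyl or that of 4-hydroxyphenyl. As far as these compounds go, it is also open whether the gap between the two hydroxyphenyl groups would survive with chlorine in place of the bromine on the shared core.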